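The source may hold more compounds than are shown below. What is called first, only, known or untested is meant among the compounds shown, and "the series" means these compounds.

Compound 2 `Cc1cccc(Oc2ccc(C#N)cc2S(=O)(=O)NC(=O)NC(C)C)c1` stands second highest of the three numbers measured in a functional assay on HEK293 cells for antagonist activity at thromboxane A2 receptor (Homo sapiens), read by fluorescence and calcium flux (on this read-out lower numbers stand for stronger inhibition and higher numbers for weaker inhibition), where compound 2 gives 1690 nM. Compound 1 `Cc1ccccc1Oc1ccc(C#N)cc1S(=O)(=O)NC(=O)NC(C)C` gives 6130 nM, and compound 3 `CCCCCNC(=O)NS(=O)(=O)c1cc(C#N)ccc1Oc1cccc(C)c1` gives 680 nM. Compound 4 `CC(C)NC(=O)NS(=O)(=O)c1cc(C#N)ccc1Oc1ccc(F)cc1` differs from compound 2 by 4-fluorophenyl in place of 3-methylphenyl on an oxygen on an aromatic ring. Of the two measured steps, only a 3.6-fold lower number from compound 1 to compound 2 (0.56 log units; beyond the scatter) touches the same place, the phenyl on the oxygen, and it was a modest step; a 2.5-fold lower number from compound 2 to compound 3 (0.40 log units; beyond the scatter) alters the group on the amide-type nitrogen and says nothing about the aryl ring. For the measured compounds named here, no measured compound carries a fluorophenyl, so the direction of the change in compound 4 has no direct support. Because a single move of the methyl gave a 3.6-fold lower number from compound 1 to compound 2 (0.56 log units; beyond the scatter), a change of comparable size is expected, with the direction open. The expected step is a 1.5-fold higher number from compound 2 to compound 4 (0.17 log units; within the scatter). Compound 4 is therefore estimated at 2500 nM in this assay, with a range from 700 nM to 9000 nM.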

Compound 4, half-maximal inhibitory concentration: 9300 nM
For compound 4 the middle estimate is 3.7-fold (0.57 log units) below the measured one; the measured number lies above the stated range.
By their numbers in this assay, from the lowest: compound 3; then compound 2; then compounds 1 and 4 (each within the scatter of the next).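

In this assay, the group on the oxygen proved able to push the number up as well as down: 4-fluorophenyl in place of 3-methylphenyl gave a 5.5-fold higher number from compound 2 to compound 4 (0.74 log units; beyond the scatter). Set against the 2-methylphenyl group, the same 4-fluorophenyl gave a 1.5-fold higher number from compound 1 to compound 4 (0.18 log units; within the scatter), so compound 1 and compound 4 cannot be told apart, and of the three aryl groups carried with the isopropyl group, only the 3-methylphenyl of compound 2 stands apart from the other two. Nothing measured here accounts for this difference.

The step from compound 2 to compound 4 changes both the substituent and its place on the ring, so the two effects remain unseparated; a 3-fluorophenyl or a 4-methylphenyl group would divide them. On these data alone, it also remains open whether the pentyl group of compound 3 would shift the number in the same way when paired with 4-fluorophenyl.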